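A shorter side chain on compound 2

A few compounds are considered here, and "the series" means these few. Any claim that something is new, unique, unknown or untested is made for them only; others in the source may bear on it.

Of the compounds shown here, two have so far been tested in a functional assay on A549 cells (Homo sapiens) for antiproliferative activity, read by XTT assay, with a stated time of 72 h; on this read-out higher numbers stand for weaker inhibition and lower numbers for stronger inhibition. Compound 1 (`C=C(C)CC[C@]1(C)C2=CCC[C@](C)(C[C@H](O)c3ccoc3)[C@H]2CC[C@H]1C`) gives 34000 nM. Compound 2 (`C=C(C)CCC[C@]1(C)C2=CCC[C@](C)(C[C@@H](O)C3=CC(=O)OC3O)[C@H]2CC[C@H]1C`) gives 3800 nM, the lower of the two numbers and so the stronger inhibition, and the gap between them lies beyond the usual scatter of repeated measurements. These two compounds differ in more than one place, so their gap cannot be tied to any single change.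

Compound 3 (`C=C(C)CC[C@]1(C)C2=CCC[C@](C)(C[C@@H](O)C3=CC(=O)OC3O)[C@H]2CC[C@H]1C`) has not yet been measured. It departs from compound 2 in one place: 1-methylethenyl in place of 2-methylprop-2-en-1-yl on a saturated chain carbon, two bonds along the chain from a saturated ring carbon. Put simply, 1-methylethenyl stands in place of 2-methylprop-2-en-1-yl on a saturated chain carbon, two bonds along the chain from a saturated ring carbon. Among the measured compounds shown here, no measured pair yet shows what a change of this kind does in this assay, so the expectation is cautious: no step beyond the scatter and no firm direction. The expected change is a 1.2-fold higher number from compound 2 to compound 3 (0.07 log units; within the scatter), which stays within the scatter. For compound 3 the estimated value is 4500 nM, with an expected range from 1800 nM to 11000 nM.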

Compound 3, half-maximal inhibitory concentration: 4400 nM
The estimate for compound 3 lay 1.0-fold (0.01 log units) above the measured number; low and high end bracket the measured number.
By their numbers in this assay, from the lowest: compounds 2 and 3 (each within the scatter of the next); then compound 1.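

In this assay, putting 1-methylethenyl in place of 2-methylprop-2-en-1-yl gives a 1.2-fold higher number from compound 2 to compound 3 (0.06 log units; within the scatter), so at this position, on a saturated chain carbon, two bonds along the chain from a saturated ring carbon, this single change leaves the number within the scatter. Among the compounds shown here, compound 3 also allows the first comparison that isolates the other end of the molecule, which compound 1 and compound 2 could not do because they differ in more than one place: a group of 9 heavy atoms with a five-membered non-aromatic ring, in place of a group of 7 heavy atoms with a five-membered aromatic ring, gives a 7.7-fold lower number from compound 1 to compound 3 (0.89 log units; beyond the scatter), a step beyond the scatter. Nothing measured here accounts for either step.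

The compounds shown leave open whether a chain ending in something other than these two hydrocarbon groups, such as an amine or a carboxylic acid, would also stay within the scatter at this position. They also leave open which part of the group of 9 heavy atoms goes with the lower number of compound 3.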